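Amide Nitrogen Groups and Paw Edema Inhibition

The source may report more compounds than this note shows. Statements on the series, on what has been measured and on what is new or still open speak of the compounds shown alone.

Compound 1 `COc1cc2c(cc1OC)C(CC(N)=O)CC2` gives 31% in a functional assay on the whole organism (strain Wistar) for inhibition, with Rattus norvegicus as the target, read by paw edema, with stated times of 60 min and 2 h, at a dose of 100 mg/kg by the oral route; on this read-out lower numbers stand for less inhibition and higher numbers for more inhibition at the one dose given (going by the name of the read-out).
Compound 2 `CCCNC(=O)CC1CCc2cc(OC)c(OC)cc21` gives 28% in this assay.
Compound 3 `COc1cc2c(cc1OC)C(CC(=O)NC(C)C)CC2` gives 37% in this assay.

Compound 3 stands highest of the three numbers, but a number 6 percentage points higher from compound 1 to compound 3 (within the scatter) and a number 9 percentage points higher from compound 2 to compound 3 (within the scatter), both inside the scatter, so nothing separates it from the others. Compound 4 `COc1cc2c(cc1OC)C(CC(=O)NC(C)(C)C)CC2` differs from compound 3 by methyl in place of hydrogen on a saturated chain carbon bound to an amide-type nitrogen and two saturated chain carbons. Going by the values given here, the steps that bear on it all alter the group on the amide-type nitrogen: a number 3 percentage points lower from compound 1 to compound 2 (within the scatter), a number 6 percentage points higher from compound 1 to compound 3 (within the scatter) and a number 9 percentage points higher from compound 2 to compound 3 (within the scatter). None moved the read-out beyond the scatter. From compound 3 to compound 4 the expected change is therefore none beyond the scatter, a number 1 percentage points lower from compound 3 to compound 4 (within the scatter). Compound 4 is expected to give 36% in this assay, between 22% and 50%.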

Compound 4, a percentage reported as inhibition, in the whole organism at one dose (the size of the read-out at that dose, not a potency): 32%
Estimate against measurement, compound 4: 4 percentage points above; low and high end bracket the measured number.
By their numbers in this assay, from the lowest: compounds 2, 1, 4 and 3 (each within the scatter of the next).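

Replacing isopropyl with tert-butyl on the amide-type nitrogen leaves this assay without a change beyond the scatter (a number 5 percentage points lower from compound 3 to compound 4 (within the scatter)). Tert-butyl also stays within the scatter of the other two groups (a number 4 percentage points higher from compound 2 to compound 4 (within the scatter); a number 1 percentage points higher from compound 1 to compound 4 (within the scatter)), so hydrogen, propyl, isopropyl and tert-butyl at this position cannot be told apart by this read-out. No measurement on hand speaks to why the read-out stays this level.

The compounds shown leave open whether a phenyl ring, a longer chain or a carboxylic acid on this nitrogen would move the number beyond the scatter.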